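The compounds below may be only part of what the source reports. "The series", "measured", "known", "first", "only" and "open" are said of these compounds alone.

Series notes. For the measured compounds named here, compound 1 `Cc1ccc(C(=O)N/N=C/c2ccccc2)c(O)c1` gives 578000 nM in an ADME assay on cells (Mus musculus, strain BALB/C) for cytotoxicity, read by MTT assay, with a stated time of 24 h (a lower number here means that less compound is tolerated, a higher number that more compound is tolerated), one of only two numbers so far; the other belongs to compound 2 `Cc1ccc(C(=O)N/N=C/c2cccc(Cl)c2)c(O)c1`, which gives 636000 nM in this assay, within the scatter of compound 1. Going by the values given here, the single measured step, a 1.1-fold higher number from compound 1 to compound 2 (0.04 log units; within the scatter), is the whole of the comparison set. Compound 3 `Cc1ccc(C(=O)N/N=C/c2ccccc2[N+](=O)[O-])c(O)c1` is next for this assay; it differs from compound 1 by nitro in place of hydrogen on an aromatic carbon. Among the compounds with values here, no measured step places nitro where hydrogen stood, so that change is uncharted here. Within the data shown here, the only step that bears on it, a 1.1-fold higher number from compound 1 to compound 2 (0.04 log units; within the scatter), shows that one substituent entering on an aromatic carbon of this core left the number within the scatter. No step beyond the scatter is therefore expected in this assay, and the expected step is a 1.0-fold lower number from compound 1 to compound 3 (0.01 log units; within the scatter). The estimate for compound 3 is 560000 nM, with an expected range from 280000 nM to 1120000 nM.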

Compound 3, half-maximal cytotoxic concentration: 644000 nM
The estimate for compound 3 lay 1.2-fold (0.06 log units) below the measured number, and the stated range covers the measured number.
By their numbers in this assay, from the lowest: compounds 1, 2 and 3 (each within the scatter of the next).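

In this assay, nitro in place of hydrogen on an aromatic carbon, ortho to a large group, gives a 1.1-fold higher number from compound 1 to compound 3 (0.05 log units; within the scatter) and so stays within the scatter. For the compounds shown here, this is the first measured change at a place ortho to a large group, and the first to bring in a group of 3 heavy atoms with 2 hydrogen-bond acceptors; in this one comparison, neither feature produces a step beyond the scatter. No measurement available here accounts for this result.

As far as these compounds go, whether an amine or a carboxylic acid at this same place would also stay within the scatter remains open, as does the outcome for nitro on other aromatic carbons of this ring. Also open, from the compounds shown here alone, is whether in this assay any single change to the shared core gives a step beyond the scatter.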